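The compounds below may be only part of what the source reports. "The series", "measured", "known", "first", "only" and "open" are said of these compounds alone.

Measured compounds:
compound 1 `Nc1ccccc1NC(=O)c1ccc(CSC(=S)N2CCc3cc(Cl)ccc32)cc1` — in a functional assay on MGC-803 cells (Homo sapiens) for antiproliferative activity, read by CCK-8 assay, with a stated time of 72 h, tested at 8 uM (a higher number here means a stronger effect of the compound at the concentration tested, a lower number a weaker effect), compound 1 gives 82.2%
compound 2 `CC1CCCCN1C(=S)SCc1ccc(C(=O)Nc2ccccc2N)cc1` — compound 2 gives 86.9%
compound 3 `CN1CCN(C(=S)SCc2ccc(C(=O)Nc3ccccc3N)cc2)CC1` — compound 3 gives 84.4%

Compound 3 stands within the scatter of both neighbours: against compound 1 the step is a number 2.2 percentage points higher from compound 1 to compound 3 (within the scatter), and against compound 2 it is a number 2.5 percentage points lower from compound 2 to compound 3 (within the scatter). The three compounds share one core and differ only in the group on the thiocarbonyl carbon, and every exchange among them has stayed within the scatter, including a number 4.7 percentage points higher from compound 1 to compound 2 (within the scatter).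

Compound 4 `CN(Cc1ccncc1)C(=S)SCc1ccc(C(=O)Nc2ccccc2N)cc1` continues the same kind of exchange: methyl((pyridin-4-yl)methyl)amino in place of 4-methylpiperazin-1-yl on a thiocarbonyl carbon. The entering group is an open-chain amine rather than a ring bound through nitrogen, which none of the three measured compounds carries, so the measured steps bear on it only by analogy. Since each of those steps was within the scatter, no step beyond the scatter is expected here either; the estimated step is a number 1.4 percentage points lower from compound 3 to compound 4 (within the scatter). Compound 4 is therefore expected to give 83%, with a range from 68% to 92%.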

Compound 4, a percentage reported as inhibition, at one concentration (the size of the read-out at that concentration, not a potency): 83.2%
Compound 4: middle estimate off by 0.2 percentage points, on the low side; the measured number falls inside the stated range.
By their numbers in this assay, from the lowest: compounds 1, 4, 3 and 2 (each within the scatter of the next).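

In this assay, methyl((pyridin-4-yl)methyl)amino brings an open-chain amine carrying a six-membered aromatic ring onto the thiocarbonyl carbon, and the read-out does not leave the scatter against any earlier compound: a number 1.2 percentage points lower from compound 3 to compound 4 (within the scatter), a number 3.7 percentage points lower from compound 2 to compound 4 (within the scatter), and a number 1 percentage points higher from compound 1 to compound 4 (within the scatter). Among these four compounds, then, this position accepts an amine that is not part of a ring bound through nitrogen, and the exchange can place an aromatic ring further out on the chain without a step beyond the scatter. Nothing available explains this tolerance.

All four values come from a single concentration, so they tell only the size of the effect at that concentration and leave open whether any compound would give a stronger or weaker effect at another concentration. Also open, as far as these compounds go, is whether an ethoxy group on the thiocarbonyl carbon, or a carboxylic acid at the end of an open chain on that nitrogen, would keep the read-out within this scatter.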